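Changing the side chain of compound 1

This account rests on a few compounds, and the source may have more. Where it says the series, first, only, none or still open, it means among the compounds named here.

- compound 1 `CNC(=O)c1cc(N)c(Nc2ccc(C#N)cc2)cc1Oc1c(C)cc(CCC#N)cc1C`: 8.28 ug/mL
- compound 2 `COC(=O)c1cc(N)c(Nc2ccc(C#N)cc2)cc1Oc1c(C)cc(CCC#N)cc1C`: 1.21 ug/mL
- compound 3 `Cc1cc(CCC#N)cc(C)c1Oc1cc(Nc2ccc(C#N)cc2)c(N)cc1C(N)=O`: 0.06 ug/mL

In a physicochemical assay for solubility, with a stated time of 4 h, at pH 7.4 (on this read-out lower numbers stand for lower solubility and higher numbers for higher solubility), compound 1 stands highest of the three. Compound 4 `CNC(=O)c1cc(N)c(Nc2ccc(C#N)cc2)cc1Oc1c(C)cc(/C=C/C#N)cc1C` carries 2-cyanoethenyl in place of 2-cyanoethyl on an aromatic carbon. All measured steps lie elsewhere, at the carbonyl group: a 6.8-fold lower number from compound 1 to compound 2 (0.84 log units; beyond the scatter) is modest, while a 140-fold lower number from compound 1 to compound 3 (2.14 log units; beyond the scatter) and a 20-fold lower number from compound 2 to compound 3 (1.30 log units; beyond the scatter) are large. They show how far these three compounds spread, but none tests this chain, so their sizes do not carry over. With compound 1 at the top at 8.28 ug/mL, a small step down is the likelier outcome. The expected step is a 2.4-fold lower number from compound 1 to compound 4 (0.37 log units; beyond the scatter). The estimate for compound 4 is 3.5 ug/mL, with an expected range of 0.9 ug/mL to 12 ug/mL.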

Compound 4, solubility: 1.32 ug/mL
Compound 4: the middle estimate sits 2.7-fold (0.42 log units) above what was measured, and the stated range covers the measured number.
By their numbers in this assay, from the lowest: compound 3; then compounds 2 and 4 (each within the scatter of the next); then compound 1.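

Among these compounds, this is the first measured step at the chain itself, and it shows that the position is not silent: replacing 2-cyanoethyl with 2-cyanoethenyl adds only a double bond, yet gives a 6.3-fold lower number from compound 1 to compound 4 (0.80 log units; beyond the scatter). Nothing available here gives a cause for this step.

Going by these compounds, it remains open whether the same change would give a similar step with the carbonyl groups of compound 2 or compound 3. Also open, on these data alone, is how a longer chain, an amine or a carboxylic acid at this position would read in this assay.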